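Swapping Methylsulfonyl for Methylsulfanyl: Predicting Compound 4

The source may report more compounds than this note shows. Statements on the series, on what has been measured and on what is new or still open speak of the compounds shown alone.

Three measured compounds share a common core and have been tested in an assay for binding affinity to Alpha-1B adrenergic receptor (Homo sapiens), read by radioligand binding; a lower number here means a stronger inhibitor, a higher number a weaker inhibitor. Compound 1 `CSc1ccc(C)cc1NCC1=NCCN1` gives 123 nM. Compound 2 `Cc1ccc(S(C)(=O)=O)c(NCC2=NCCN2)c1` gives 3470 nM, and compound 3 `CS(=O)(=O)c1cc(F)ccc1NCC1=NCCN1` gives 513 nM. Compounds 2 and 1 differ in a single place: methylsulfanyl in place of methylsulfonyl on an aromatic carbon This change produced a step of a 28-fold lower number from compound 2 to compound 1 (1.45 log units; beyond the scatter). Compound 3 stands second highest of the three numbers; its nearest neighbour is compound 1 and its furthest is compound 2. How the core of compound 3 differs from the core of compound 2 is not broken down here.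

Compound 4 `CSc1cc(F)ccc1NCC1=NCCN1` has not yet been measured. Among the compounds with values here, it differs from compound 3 in one place: methylsulfanyl in place of methylsulfonyl on an aromatic carbon This is the same kind of change as the one from compound 2 to compound 1, but the surroundings are not identical: in compound 2 the changing group is para to a methyl group, whereas in compound 3 it is meta to a fluoro group. Because the earlier change gave a 28-fold lower number from compound 2 to compound 1 (1.45 log units; beyond the scatter), a step of broadly similar size is expected here, and the expected step is a 21-fold lower number from compound 3 to compound 4 (1.31 log units; beyond the scatter). The surroundings differ, so the expectation is held a little less firmly than the earlier step alone would suggest. Compound 4 is therefore estimated at 25 nM in this assay, with a likely range from 8 nM to 80 nM.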

Compound 4, inhibition constant: 15.1 nM
For compound 4 the middle estimate is 1.7-fold (0.22 log units) above the measured one; measured number inside the range.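

Putting methylsulfanyl in place of methylsulfonyl gives a 34-fold lower number from compound 3 to compound 4 (1.53 log units; beyond the scatter) in this assay, and the change carries over from one core to the other at much the same size: the same change on two cores in this assay, a 28-fold lower number (1.45 log units; beyond the scatter) from compound 2 to compound 1 and a 34-fold lower number (1.53 log units; beyond the scatter) from compound 3 to compound 4, 1.2-fold (0.08 log units) apart, within the scatter of two such steps

In these two pairs, then, the swap behaves almost like a fixed step, even though one core carries a methyl group and the other a fluoro group, so the step seen on one core was a useful guide to the other. Two pairs are a small sample. They do not show that the step is constant across the series, and they show nothing about why the swap lowers the number or whether it would do the same in any other assay.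

The compounds shown leave open how other groups would compare in the same place, such as methylsulfinyl, methoxy, an amine or a longer chain like ethylsulfanyl. They also leave open whether the step would keep its size on a core carrying a chloro or trifluoromethyl group instead of the methyl or fluoro group.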